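Chain Variation on the Aromatic Nitrogen: Compounds 1 to 4

The compounds below may be only part of what the source reports. "The series", "measured", "known", "first", "only" and "open" are said of these compounds alone.

Measured so far in a functional assay on MCF7 cells (Homo sapiens) for antiproliferative activity; on this read-out higher numbers stand for weaker inhibition and lower numbers for stronger inhibition:
compound 1 `CCCn1c(Cc2cc(OC)c(OC)c(OC)c2)nc2c(N)ncnc21` gives 46800 nM
compound 2 `CC/C=C\Cn1c(Cc2cc(OC)c(OC)c(OC)c2)nc2c(N)ncnc21` gives 64600 nM
compound 3 `COc1cc(Cc2nc3c(N)ncnc3n2CC2CCC2)cc(OC)c1OC` gives 45700 nM

All three numbers sit close together. The step of a 1.4-fold higher number from compound 1 to compound 2 (0.14 log units; within the scatter) and the step of a 1.0-fold lower number from compound 1 to compound 3 (0.01 log units; within the scatter) both stay within the scatter, as does a 1.4-fold lower number from compound 2 to compound 3 (0.15 log units; within the scatter). Compound 3 has the lowest of the three numbers, but its nearest neighbour, compound 1, is within the scatter, and so is compound 2, so no ordering among the three can be read from these data.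

Compound 4 `COCCn1c(Cc2cc(OC)c(OC)c(OC)c2)nc2c(N)ncnc21` is not yet measured. The change from compound 3 is methoxymethyl in place of cyclobutyl on a saturated chain carbon bound to an aromatic nitrogen. Within the data shown here, none of the measured steps covers this particular exchange; the three known steps only show that swapping ethyl, but-1-en-1-yl and cyclobutyl at this saturated chain carbon bound to an aromatic nitrogen left the read-out unchanged beyond the scatter. On that basis the expected step of a 1.1-fold higher number from compound 3 to compound 4 (0.02 log units; within the scatter) is none beyond the scatter. Compound 4 is therefore estimated at 48000 nM, with a range from 20000 nM to 115000 nM, the width reflecting that methoxymethyl brings one hydrogen-bond acceptor and no ring, a kind of change that the measured steps have not sampled.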

Compound 4, half-maximal inhibitory concentration: 64600 nM
Beside the measured number, compound 4's estimate is 1.3-fold (0.13 log units) below it, and the stated range covers the measured number.
By their numbers in this assay, from the lowest: compounds 3, 1, 2 and 4 (each within the scatter of the next).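

In this assay, methoxymethyl in place of cyclobutyl on a saturated chain carbon bound to an aromatic nitrogen gives a 1.4-fold higher number from compound 3 to compound 4 (0.15 log units; within the scatter), so bringing in a hydrogen-bond acceptor and removing the four-membered ring leaves the read-out within the scatter. The open-chain comparisons read the same way: methoxymethyl in place of but-1-en-1-yl gives no change at the digits printed from compound 2 to compound 4 (within the scatter), and methoxy in place of methyl on a saturated chain carbon, two bonds along the chain from an aromatic nitrogen, gives a 1.4-fold higher number from compound 1 to compound 4 (0.14 log units; within the scatter). All the steps among the four compounds therefore lie within the scatter, now including a substituent with oxygen as well as all-carbon ones, and no supporting data are available to account for this flat picture.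

From the compounds shown here alone, what an amine, a carboxylic acid or a longer chain at this position would do to the read-out remains open. Also open is whether any group here can produce a step beyond the scatter, as none of the compounds shown gives such a step.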